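Swapping an Amide for a Dichlorophenyl Sulfone

The source may hold more compounds than are shown below. What is called first, only, known or untested is meant among the compounds shown, and "the series" means these compounds.

Compound 1, `Cn1c(=O)c(S(=O)(=O)Cc2ccc(F)cc2)cc2cnc(Nc3ccc4[nH]ccc4c3)nc21`, gives 30000 nM in a functional assay on K562 cells (Homo sapiens) for inhibition, read by trypan blue exclusion, with a stated time of 72 h; a lower number here means a stronger inhibitor, a higher number a weaker inhibitor.
Compound 2, `Cn1c(=O)c(S(=O)(=O)Nc2ccc(F)cc2F)cc2cnc(Nc3ccc4[nH]ccc4c3)nc21`, gives 5000 nM.
Compound 3, `Cn1c(=O)c(C(=O)Nc2ccc(F)cc2F)cc2cnc(Nc3ccc4[nH]ccc4c3)nc21`, gives 5000 nM.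

Compound 3 sits level with compound 2 at the digits shown; together they carry the lowest numbers of the three, with compound 1 the furthest away. Compound 4, `Cn1c(=O)c(S(=O)(=O)c2ccc(Cl)cc2Cl)cc2cnc(Nc3ccc4[nH]ccc4c3)nc21`, differs from compound 3 by (2,4-dichlorophenyl)sulfonyl in place of (2,4-difluorophenyl)carbamoyl on an aromatic carbon. The steps of a 6.0-fold lower number from compound 1 to compound 2 (0.78 log units; beyond the scatter) and a 6.0-fold lower number from compound 1 to compound 3 (0.78 log units; beyond the scatter) both bear on this change: each replaced the (4-fluorobenzyl)sulfonyl group of compound 1 and each gave a modest gain. Compound 4 keeps a sulfonyl like compound 1 but carries the aromatic ring directly, like compound 2; a small loss against compound 3 is therefore expected, a 1.6-fold higher number from compound 3 to compound 4 (0.20 log units; within the scatter). Compound 4 is estimated at 8000 nM, within 2000 nM to 40000 nM.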

Compound 4, half-maximal inhibitory concentration: 1000 nM
Compound 4: the middle estimate sits 8.0-fold (0.90 log units) above what was measured; measured number outside the range, below it.
By their numbers in this assay, from the lowest: compound 4; then compounds 2 and 3 (each within the scatter of the next); then compound 1.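

At this aromatic carbon, a sulfonyl carrying the ring directly does better than the amide (a 5.0-fold lower number from compound 3 to compound 4 (0.70 log units; beyond the scatter)). The same 2,4-dichlorophenyl on the sulfonyl sulfur also does better than the (2,4-difluorophenyl)amino group (a 5.0-fold lower number from compound 2 to compound 4 (0.70 log units; beyond the scatter)) and the 4-fluorobenzyl group (a 30-fold lower number from compound 1 to compound 4 (1.48 log units; beyond the scatter)), so a sulfonyl at this position is compatible with the lowest number of the four. No measurement here explains this gain.

Each step changes the halogens along with the link to the ring, so the contribution of the chlorine atoms remains unseparated. Going by these compounds, how a ring bearing an amine or a carboxylic acid would behave here also remains open.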